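The compounds below may be only part of what the source reports. "The series", "measured", "known", "first", "only" and "open" are said of these compounds alone.

Measured compounds:
Compound 1, `O=C(O)c1cccc(Cc2c(-c3ccccc3)nn3cc(Br)ccc23)n1`: 11 nM
Compound 2, `O=C(O)c1cccc(Cc2c(-c3ccccc3)nn3cc(C4CC4)ccc23)n1`: 190 nM

Both were tested in a functional assay on cells for antagonist activity at prostaglandin E2 receptor EP1 subtype (Rattus norvegicus), read by fluorescence and calcium flux, with a stated time of 60 s; on this read-out lower numbers stand for stronger inhibition and higher numbers for weaker inhibition. For the measured compounds named here, compound 2 gives the highest number of the two, with compound 1 as its only neighbour, and the step of a 17-fold higher number from compound 1 to compound 2 (1.24 log units; beyond the scatter) is large and beyond the scatter. Compound 3, `CS(=O)(=O)c1ccc2c(Cc3cccc(C(=O)O)n3)c(-c3ccccc3)nn2c1`, has not yet been measured. It differs from compound 2 in one place: methylsulfonyl in place of cyclopropyl on an aromatic carbon. Going by the values given here, the only measured step bearing on this position is a 17-fold higher number from compound 1 to compound 2 (1.24 log units; beyond the scatter), which shows that exchanging the group there can move the number a long way. Methylsulfonyl resembles neither bromo nor cyclopropyl in what is counted, so the direction of the step to compound 3 is uncertain; a step of some size is expected, more likely downward than upward. The estimate for compound 3 is 80 nM, with a range from 15 nM to 500 nM, corresponding to an expected step of a 2.4-fold lower number from compound 2 to compound 3 (0.38 log units; beyond the scatter).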

Compound 3, half-maximal inhibitory concentration: 5400 nM
Compound 3: middle estimate off by 68-fold (1.83 log units), on the low side; measured number outside the range, above it.
By their numbers in this assay, from the lowest: compound 1; then compound 2; then compound 3.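

At this aromatic carbon, the rise seen on going from bromo to cyclopropyl is not the upper end of what an exchange can do: methylsulfonyl in place of cyclopropyl gives a 28-fold higher number from compound 2 to compound 3 (1.45 log units; beyond the scatter) and, set against bromo, a 490-fold higher number from compound 1 to compound 3 (2.69 log units; beyond the scatter) on the same carbon. Across these three compounds, the number therefore depends strongly on the group at this one place, and methylsulfonyl, the only one of the entering groups here counted with hydrogen-bond acceptors, gives the highest number. Nothing measured on these compounds explains why the number climbs at this position.

From the compounds shown here alone, whether an amine, a methoxy group or a methylthio group at this carbon would stay close to bromo or move toward methylsulfonyl remains open. So does whether the sulfur or the two oxygens of methylsulfonyl go with the rise, which a methyl ketone or a chlorine could begin to separate.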